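Quinoxaline diamines: a sulfanyl swap on the core

The source may report more compounds than this note shows. Statements on the series, on what has been measured and on what is new or still open speak of the compounds shown alone.

Measured compounds:
compound 1 `Nc1cc(N)c2nc(-c3ccccc3)c(Oc3ccc(Cl)c(Cl)c3)nc2c1` — 28800 nM
compound 2 `CCOC(=O)[C@H](CCC(=O)O)NC(=O)c1ccc(Sc2nc3cc(N)cc(N)c3nc2-c2ccccc2)cc1` — 32400 nM
compound 3 `COc1ccc(CNc2nc3cc(N)cc(N)c3nc2-c2ccccc2)cc1` — 31600 nM

In a functional assay on SK-MEL-5 cells (Homo sapiens) for inhibition, read by sulforhodamine B assay, with a stated time of 48 h (a lower number here means a stronger inhibitor of growth, a higher number a weaker inhibitor of growth), compound 1 gives 28800 nM. Of the three numbers this is the smallest, yet its separation from compound 3 and from compound 2 lies within the scatter in both cases, so the three compounds cannot be told apart on these data. All share the same diamine-bearing core, differing only in the group attached to it.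

Compound 4 `Nc1cc(N)c2nc(-c3ccccc3)c(Sc3ccc(F)cc3)nc2c1` is not yet measured. It arises from compound 1 by the change ((4-fluorophenyl)sulfanyl in place of 3,4-dichlorophenoxy on an aromatic carbon). Among the measured compounds shown here, since no measured pair differs in one place, no step can be drawn on from these data, and the three measured values give no hint that the group at this place moves the number far. A step from compound 1 to compound 4 no larger than the scatter is therefore expected, with no direction favoured, which means an expected step of a 1.0-fold higher number from compound 1 to compound 4 (0.02 log units; within the scatter). Compound 4 is estimated at 30000 nM in this assay, with a range from 10000 nM to 90000 nM.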

Compound 4, concentration for total growth inhibition: 33100 nM
Beside the measured number, compound 4's estimate is 1.1-fold (0.04 log units) below it, and the stated range covers the measured number.
By their numbers in this assay, from the lowest: compounds 1, 3, 2 and 4 (each within the scatter of the next).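

Among the compounds shown here, compound 4 supplies the first pair in this set that differs in one place. In this assay, putting (4-fluorophenyl)sulfanyl in place of 3,4-dichlorophenoxy on the aromatic carbon next to the ring nitrogen gives a 1.1-fold higher number from compound 1 to compound 4 (0.06 log units; within the scatter), a step within the scatter. At this place, then, an oxygen and two chlorine atoms can leave and a sulfur and a fluorine can enter with no difference these data can detect, and nothing available bears on why the two groups read alike.

As far as these compounds go, both groups carry a six-membered aromatic ring of carbon only, so it remains open whether a morpholine or a short alkyl chain at this place would read differently. The sulfur and fluorine also enter together, which leaves the contribution of each unresolved.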